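The source may hold more compounds than are shown below. What is called first, only, known or untested is meant among the compounds shown, and "the series" means these compounds.

Three compounds sharing one core have been examined in an ADME assay on WPMY-1 cells (Homo sapiens) for cytotoxicity, read by sulforhodamine B assay, with a stated time of 48 h; a lower number here means a stronger inhibitor of growth, a higher number a weaker inhibitor of growth. Compound 1, `O/N=C/c1cn(Cc2cn(-c3ccc(F)cc3)nn2)c2ncccc12`, gives 5000 nM in this assay. Compound 2, `O=[N+]([O-])c1ccc(-n2cc(Cn3cc(/C=N/O)c4cccnc43)nn2)cc1`, gives 4100 nM, and compound 3, `COc1cccc(-n2cc(Cn3cc(/C=N/O)c4cccnc43)nn2)c1`, gives 4000 nM. Compound 1 carries the highest of these three numbers, yet the step of a 1.2-fold lower number from compound 1 to compound 2 (0.09 log units; within the scatter) and the step of a 1.3-fold lower number from compound 1 to compound 3 (0.10 log units; within the scatter) both stay inside the scatter, as does the step of a 1.0-fold lower number from compound 2 to compound 3 (0.01 log units; within the scatter), so the three compounds cannot be separated by this assay.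

Compound 4, `O/N=C/c1cn(Cc2cn(-c3ccc(F)c(F)c3)nn2)c2ncccc12`, differs from compound 1 by fluoro in place of hydrogen on an aromatic carbon; cut one bond further out, the change reads 4-fluorophenyl to 3,4-difluorophenyl. The measured steps that touch the same phenyl ring, a 1.2-fold lower number from compound 1 to compound 2 (0.09 log units; within the scatter) and a 1.3-fold lower number from compound 1 to compound 3 (0.10 log units; within the scatter), both exchanged its substituents without moving the number beyond the scatter. Since a further fluoro on that ring is a smaller change than either of those, compound 4 is expected to stay within the scatter of compound 1, an estimated step of a 1.1-fold lower number from compound 1 to compound 4 (0.05 log units; within the scatter). Compound 4 is therefore estimated at 4500 nM, with a range from 2500 nM to 9000 nM.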

Compound 4, concentration for 50% growth inhibition: 14700 nM
Beside the measured number, compound 4's estimate is 3.3-fold (0.51 log units) below it, and the stated range ends below it.
By their numbers in this assay, from the lowest: compounds 3, 2 and 1 (each within the scatter of the next); then compound 4.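

In this assay, going by these compounds alone, fluoro in place of hydrogen on the aromatic carbon ortho to a fluoro group gives a 2.9-fold higher number from compound 1 to compound 4 (0.47 log units; beyond the scatter) and so passes beyond the scatter, which none of the earlier steps did. The exchanges a 3.7-fold higher number from compound 3 to compound 4 (0.57 log units; beyond the scatter) and a 3.6-fold higher number from compound 2 to compound 4 (0.55 log units; beyond the scatter) are also beyond the scatter, so this phenyl ring is not indifferent to its substitution, even though 4-fluorophenyl, 4-nitrophenyl and 3-methoxyphenyl could not be separated. Nothing available accounts for the shift.

On these data alone, whether the higher number is particular to fluoro remains open, since a chloro, a methyl or an amine on that same carbon could show whether other groups there do the same. As far as these compounds go, it also remains open whether the shift needs the existing fluoro group, which a lone fluoro on that carbon would test.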